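A few compounds are considered here, and "the series" means these few. Any claim that something is new, unique, unknown or untested is made for them only; others in the source may bear on it.

Compound 1 `COc1ccc(CN2CCc3nc(-c4ccccn4)nc(N4CCN(CCN(C)C)CC4)c3C2)cc1` was tested in an assay on FRT cells with Cystic fibrosis transmembrane conductance regulator variant F508del (Homo sapiens) as the target, read by fluorescence, with a stated time of 25 min (a higher number here means a larger maximal response, a lower number a smaller maximal response), and came out as "not active" (no number reported), so there is no single number to set it against the other two compounds. Those two do carry numbers: compound 2 `COc1ccc(CN2CCc3nc(-c4ccccn4)nc(N4CCC(C(N)=O)CC4)c3C2)cc1` reaches 86.6% in this assay, and compound 3 `COc1ccc(CN2CCc3nc(-c4ccccn4)nc(N4CCN(CC(N)=O)CC4)c3C2)cc1` reaches 35.9%. Among the measured compounds shown here, the only step measured between neighbouring structures runs between them, a number 50.7 percentage points lower from compound 2 to compound 3 (beyond the scatter), and it concerns a change at a quite different part of the shared core, where a 4-carbamoylmethyl piperazinyl replaces a 4-carbamoylpiperidinyl.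

Compound 4 `CN(C)CCN1CCN(c2nc(-c3ccccn3)nc3c2CN(CC2CCCCC2)CC3)CC1` keeps the whole framework of compound 1 and changes only the group hanging from the ring nitrogen:

cyclohexyl in place of 4-methoxyphenyl on a saturated chain carbon bound to an amine nitrogen in a ring

For the measured compounds named here, no measured step touches this part of the molecule, so the measured change from compound 2 to compound 3 says nothing directly about how much the maximal response in this assay should move here. What remains is the starting point: compound 1 gave no response worth a number. With nothing to show that a cyclohexyl rather than a 4-methoxyphenyl would lift the signal, compound 4 is expected to stay low, estimated at 15% with a likely range from 0% to 45%, and it may well again be reported simply as not active.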

Compound 4, largest response reached (Emax), in percent of the reference or control that the assay uses: 41%
Compound 4: middle estimate off by 26 percentage points, on the low side; low and high end bracket the measured number.
By their numbers in this assay, from the lowest: compounds 3 and 4 (each within the scatter of the next); then compound 2.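

In this assay compound 1 is recorded as "not active" (no number reported) and compound 4 gives 41% so no step can be read between them. The compounds shown leave open how far cyclohexyl in place of 4-methoxyphenyl moves the maximal response on this framework. No supporting data are available to explain the result for compound 4.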